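Nitro-to-bromo swap on the aryl ring of compound 1

The source may report more compounds than this note shows. Statements on the series, on what has been measured and on what is new or still open speak of the compounds shown alone.

Of the compounds shown here, two have been measured in a functional assay on MOLT-4 cells (Homo sapiens) for inhibition, read by MTT assay, with a stated time of 48 h; on this read-out higher numbers stand for weaker inhibition and lower numbers for stronger inhibition. Compound 1 `O=C(/C=C/c1ccc([N+](=O)[O-])cc1)c1ccc[nH]1` gives 15000 nM in this assay, the lower of the two numbers. Compound 2 `O=C(/C=C/c1cc([N+](=O)[O-])ccc1Cl)c1ccc[nH]1` gives 42000 nM, a gap beyond the usual scatter; compound 2 differs from compound 1 in more than one place, so no single-change step can be read from this pair.

Compound 3 `O=C(/C=C/c1ccc(Br)cc1)c1ccc[nH]1` is not yet measured. It differs from compound 1 by bromo in place of nitro on an aromatic carbon. Going by the values given here, no measured pair isolates this change, so its size is unknown. The expectation is a small step from compound 1 to compound 3, a 1.5-fold higher number from compound 1 to compound 3 (0.17 log units; within the scatter), toward a somewhat higher number, not clearly beyond the scatter. Compound 3 is thus estimated at 22000 nM in this assay, with a range from 8000 nM to 60000 nM.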

Compound 3, half-maximal inhibitory concentration: 49000 nM
Estimate against measurement, compound 3: 2.2-fold (0.35 log units) below, and the stated range covers the measured number.
By their numbers in this assay, from the lowest: compound 1; then compounds 2 and 3 (each within the scatter of the next).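

In this assay, this position now has its first single-change reading: bromo in place of nitro on the aromatic carbon gives a 3.3-fold higher number from compound 1 to compound 3 (0.51 log units; beyond the scatter), a step beyond the scatter. Compound 2 could not show this, since it differs from compound 1 in more than one place; here the change is isolated, and nitro and bromo are not interchangeable at this carbon, with nitro holding the stronger inhibition. No measured evidence on hand accounts for the step.

Going by these compounds, one pair cannot show whether nitro is favourable or bromo unfavourable at this carbon, and how a smaller or differently built group would sit on that scale, such as an amine, a carboxylic acid or a methoxy group, remains open. The effect of changes elsewhere on the shared core also remains unread.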